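A few compounds are considered here, and "the series" means these few. Any claim that something is new, unique, unknown or untested is made for them only; others in the source may bear on it.

Compound 1 `COc1cc(CCc2ccccc2)cc(OC)c1O` gives 7830 nM
Compound 2 `COc1cc(CCc2ccc(F)cc2)cc(OC)c1O` gives 5470 nM
Compound 3 `COc1cc(CCc2ccc(Cl)cc2)cc(OC)c1O` gives 8780 nM

These values come from a functional assay on HepG2 cells (Homo sapiens) for antiproliferative activity, read by MTT assay, with a stated time of 72 h; a lower number here means a stronger inhibitor, a higher number a weaker inhibitor. The three compounds share one core and differ in a single group. Compound 3 cannot be separated from the other two, since both of its steps lie within the scatter (a 1.1-fold higher number from compound 1 to compound 3 (0.05 log units; within the scatter)) and (a 1.6-fold higher number from compound 2 to compound 3 (0.21 log units; within the scatter)). The next structure, compound 4 `COc1cc(CCc2ccc([N+](=O)[O-])cc2)cc(OC)c1O`, has nitro in place of chloro on an aromatic carbon, para to a large group (nitro in place of chloro on an aromatic carbon). The remaining measured step, with fluoro in place of hydrogen (a 1.4-fold lower number from compound 1 to compound 2 (0.16 log units; within the scatter)), also stayed within the scatter. Within the data shown here, those three steps are the only guide, and none of them involves nitro, so the evidence is indirect. No step beyond the scatter is expected in either direction, although the uncertainty remains wide. The estimated step is small (a 1.3-fold lower number from compound 3 to compound 4 (0.10 log units; within the scatter)). Compound 4 is expected at 7000 nM with an estimated range from 2800 nM to 17000 nM as its likely span.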

Compound 4, half-maximal inhibitory concentration: 11000 nM
For compound 4 the middle estimate is 1.6-fold (0.20 log units) below the measured one; measured number inside the range.
By their numbers in this assay, from the lowest: compounds 2, 1, 3 and 4 (each within the scatter of the next).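

In this assay, putting nitro, with its three heavy atoms and two hydrogen-bond acceptors, in place of chloro on the aromatic carbon para to a large group does not separate the two compounds (a 1.3-fold higher number from compound 3 to compound 4 (0.10 log units; within the scatter)). The comparisons with the hydrogen and fluoro compounds also stay within the scatter (a 1.4-fold higher number from compound 1 to compound 4 (0.15 log units; within the scatter)) (a 2.0-fold higher number from compound 2 to compound 4 (0.30 log units; within the scatter)), although the step from the fluoro compound is the largest of the three. Hydrogen, fluoro, chloro and nitro at this position therefore cannot be told apart in this assay, even though nitro differs from the others in its atoms and acceptor count, and no supporting measurement offers an explanation for this.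

Going by these compounds, whether an amine, a carboxylic acid or a longer chain at this position would give a step beyond the scatter remains open. The compounds shown also leave open whether changes elsewhere on the shared core would matter more.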